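Replacing cyclohexyl with tert-butyl on a urea nitrogen

The source may hold more compounds than are shown below. What is called first, only, known or untested is meant among the compounds shown, and "the series" means these compounds.

Of the compounds shown here, three sharing one core have been tested in a functional assay on the whole organism (strain Sprague-Dawley) for inhibition, with Rattus norvegicus as the target, read by paw edema, with stated times of 30 min and 3 h, at a dose of 80 mg/kg by the oral route; on this read-out lower numbers stand for less inhibition and higher numbers for more inhibition at the one dose given (going by the name of the read-out). Compound 1 `Cc1nc2ccccc2c(=O)n1NC(=O)NC1CCCCC1` gives 88.6%, the highest of the three numbers. Compound 3 `Cc1nc2ccccc2c(=O)n1NS(=O)(=O)c1ccccc1` gives 77.3%, and compound 2 `O=c1c2ccccc2nc(CO[N+](=O)[O-])n1NS(=O)(=O)c1ccccc1` gives 55%; both lie beyond the scatter below compound 1, compound 2 furthest of all. For the measured compounds named here, the single measured step with one change, a number 22.3 percentage points higher from compound 2 to compound 3 (beyond the scatter), concerns a nitrooxy group on a saturated chain carbon and says nothing about the part of the molecule altered here.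

Compound 4 `Cc1nc2ccccc2c(=O)n1NC(=O)NC(C)(C)C` differs from compound 1 by tert-butyl in place of cyclohexyl on an amide-type nitrogen. Going by the values given here, no measured step bears on this exchange, so the expectation rests only on compound 1 itself; the step is expected to be small, and its direction uncertain. For compound 4 the estimated step from compound 1 is a number 8.6 percentage points lower from compound 1 to compound 4 (within the scatter). Compound 4 is therefore expected to give about 80% in this assay, with a likely range from 65% to 92%.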

Compound 4, a percentage reported as inhibition, in the whole organism at one dose (the size of the read-out at that dose, not a potency): 82.5%
The estimate for compound 4 lay 2.5 percentage points below the measured number, and the stated range covers the measured number.
By their numbers in this assay, from the lowest: compound 2; then compounds 3, 4 and 1 (each within the scatter of the next, the first and the last beyond it).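

Exchanging cyclohexyl for tert-butyl on the amide-type nitrogen gives a number 6.1 percentage points lower from compound 1 to compound 4 (within the scatter) in this assay, so the two compounds cannot be told apart on this read-out. At this place, then, the ring of cyclohexyl is not required for a high number at the one dose given: tert-butyl, with no ring and fewer heavy atoms, reads the same within the scatter. Nothing available here explains why the two groups read alike.

As far as these compounds go, both groups contain carbon only, so it remains open how this position would respond to a phenyl ring, a longer chain or a chain ending in an amine. A reading at one dose shows the size of the effect rather than a potency, so the two compounds could still differ at other doses.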